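Compound 3 to compound 4: one aryl group exchanged

The compounds below may be only part of what the source reports. "The series", "measured", "known", "first", "only" and "open" are said of these compounds alone.

Values in a functional assay on HCT-116 cells (Homo sapiens) for antiproliferative activity, read by MTT assay, with a stated time of 72 h; on this read-out lower numbers stand for stronger inhibition and higher numbers for weaker inhibition:
Compound 1 `O=C(CCc1cccc2c1B(O)OC2)Nc1ccccc1`: 350 nM
Compound 2 `O=C(CCc1cccc2c1B(O)OC2)Nc1cccc(-c2cccc(F)c2)c1`: 460 nM
Compound 3 `CSc1ccc(-c2cccc(NC(=O)CCc3cccc4c3B(O)OC4)c2)cc1`: 180 nM

Compound 3 stands level with compound 1: a 1.9-fold lower number from compound 1 to compound 3 (0.29 log units; within the scatter). It stands clear of compound 2: a 2.6-fold lower number from compound 2 to compound 3 (0.41 log units; beyond the scatter).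

Compound 4 `CC(=O)c1cccc(-c2cccc(NC(=O)CCc3cccc4c3B(O)OC4)c2)c1` has 3-acetylphenyl in place of 4-(methylsulfanyl)phenyl on an aromatic carbon. Within the data shown here, the closest precedent is a 2.6-fold lower number from compound 2 to compound 3 (0.41 log units; beyond the scatter), a modest swap of one such group for another at the same place. Compound 2, whose 3-fluorophenyl is named most like the entering group, gave 460 nM. A small upward move is therefore likely. The expected step in this assay is a 1.7-fold higher number from compound 3 to compound 4 (0.22 log units; within the scatter). For compound 4 the estimate is 300 nM, with an expected range of 120 nM to 750 nM.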

Compound 4, half-maximal inhibitory concentration: 86 nM
Compound 4: the middle estimate sits 3.5-fold (0.54 log units) above what was measured, outside the stated range (below it).
By their numbers in this assay, from the lowest: compound 4; then compounds 3, 1 and 2 (each within the scatter of the next, the first and the last beyond it).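

In this assay, among these compounds, adding an aryl group at this place can lower the number clearly: a 4.1-fold lower number from compound 1 to compound 4 (0.61 log units; beyond the scatter) is the first such addition to lie beyond the scatter. The added group's substituent also matters, as shown by a 2.1-fold lower number from compound 3 to compound 4 (0.32 log units; beyond the scatter) and a 5.3-fold lower number from compound 2 to compound 4 (0.73 log units; beyond the scatter). Nothing available explains this gain.

The names 4-(methylsulfanyl)phenyl and 3-acetylphenyl differ in both substituent and ring position, so these two changes cannot be separated. On these data alone, whether an amine or a carboxylic acid could match acetyl at this place remains open.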